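The source may hold more compounds than are shown below. What is called first, only, known or untested is meant among the compounds shown, and "the series" means these compounds.

Measured so far in an ADME assay on NHDF cells (Homo sapiens) for cytotoxicity, read by MTT assay, with a stated time of 72 h; on this read-out lower numbers stand for stronger inhibition and higher numbers for weaker inhibition:
- compound 1, `COc1cccc(/C=C2\CCC/C(=C\c3ccc(Cl)cc3)C2=O)c1OC`: compound 1 gives 18600 nM
- compound 2, `COc1cccc(/C=C2\CCC/C(=C\c3cccc(O)c3)C2=O)c1OC`: compound 2 gives 19300 nM
- compound 3, `COc1cccc(/C=C2\CCC/C(=C\c3cccc(Cl)c3Cl)C2=O)c1OC`: for compound 3 only a limit is reported, > 50000 nM

Compound 1 holds the lowest of the two numbers; the nearest is compound 2, and the step of a 1.0-fold higher number from compound 1 to compound 2 (0.02 log units; within the scatter) lies within the scatter. The step of an at least 2.6-fold higher number from compound 1 to compound 3 (0.42 log units; beyond the scatter) is beyond the scatter, though its size is bounded only by the limit of > 50000 nM in this assay, at which 1 of the 3 values shown sits. The step of an at least 2.5-fold higher number from compound 2 to compound 3 (0.41 log units; beyond the scatter) reads the same way.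

Compound 4, `COc1cccc(/C=C2\CCC/C(=C\c3ccc(Cl)cc3Cl)C2=O)c1OC`, is not yet measured. It differs from compound 1 by chloro in place of hydrogen on an aromatic carbon; cut one bond further out this reads 4-chlorophenyl to 2,4-dichlorophenyl. The closest measured change is the step from compound 1 to compound 3, where a chloro also enters ortho to the large group, and that step reached the limit (the limit of > 50000 nM in this assay, at which 1 of the 3 values shown sits). On that basis a higher number is expected for compound 4 in this assay, an estimated step of a 2.2-fold higher number from compound 1 to compound 4 (0.33 log units; beyond the scatter), with a fair chance that only a limit is returned. The estimate for compound 4 is 40000 nM, ranging from 18000 nM to 100000 nM.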

Compound 4, half-maximal inhibitory concentration: 49200 nM
Estimate against measurement, compound 4: 1.2-fold (0.09 log units) below; the range from low to high includes it.
By their numbers in this assay, from the lowest: compounds 1 and 2 (each within the scatter of the next); then compound 4. At a limit, above all of these: compound 3.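

In this assay, chloro in place of hydrogen on an aromatic carbon, ortho to a large group, takes 4-chlorophenyl to 2,4-dichlorophenyl and now has a measured, modest size in this series: a 2.6-fold higher number from compound 1 to compound 4 (0.42 log units; beyond the scatter). The 2,4-dichlorophenyl group also separates from the 3-hydroxyphenyl group, with a 2.5-fold higher number from compound 2 to compound 4 (0.41 log units; beyond the scatter), so compound 4 is a measured dichlorophenyl example lying clearly above both compound 1 and compound 2. The step of an at least 1.0-fold lower number from compound 3 to compound 4 (0.00 log units; that floor lies within the scatter) cannot be read, so the 2,3-dichlorophenyl and 2,4-dichlorophenyl groups remain unordered: the limit of > 50000 nM in this assay, at which 1 of the 4 values shown sits.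

As far as these compounds go, whether this rise belongs to chloro itself, or would also follow another group entering at the same place, stays open; a methyl group or an amine there would test this. From the compounds shown here alone, all four compounds keep the rest of the core of compound 1 unchanged, so it is also open whether the chloro step would keep its size with a different group on the other side of the core.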